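The compounds below may be only part of what the source reports. "The series", "measured", "known", "first", "only" and "open" are said of these compounds alone.

Measured so far:
compound 1 `Cn1cc(C2=C(c3nn(CCCn4cccc4)c4ncccc34)C(=O)N(c3ccccc3)C2=O)c2ccccc21` gives 36600 nM in a functional assay on K562 cells (Homo sapiens) for antiproliferative activity, read by MTT assay, with a stated time of 48 h; a higher number here means a weaker inhibitor, a lower number a stronger inhibitor
compound 2 `Cn1cc(C2=C(c3nn(CCCn4ccnc4)c4ncccc34)C(=O)NC2=O)c2ccccc21` gives 13800 nM in this assay

Of the two numbers, compound 2 has the lower one, and its gap to compound 1 lies beyond the scatter. The two differ in more than one place, so their gap cannot be assigned to either change alone.

Compound 3 `Cn1cc(C2=C(c3nn(CCCn4cccc4)c4ncccc34)C(=O)NC2=O)c2ccccc21` has not been measured. It differs from compound 2 in one place: 1H-pyrrol-1-yl in place of 1H-imidazol-1-yl on a saturated chain carbon, three bonds along the chain from an aromatic nitrogen. Among the measured compounds shown here, the change is small in size, and no measured pair isolates its effect.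

With no guide from the measured pairs, the step is expected to be modest, estimated as a 1.4-fold higher number from compound 2 to compound 3 (0.16 log units; within the scatter). Compound 3 is thus estimated at 20000 nM in this assay, within a range of 7000 nM to 60000 nM.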

Compound 3, half-maximal inhibitory concentration: 21600 nM
Beside the measured number, compound 3's estimate is 1.1-fold (0.03 log units) below it, and the stated range covers the measured number.
By their numbers in this assay, from the lowest: compounds 2, 3 and 1 (each within the scatter of the next, the first and the last beyond it).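

In this assay, 1H-pyrrol-1-yl in place of 1H-imidazol-1-yl on a saturated chain carbon gives a 1.6-fold higher number from compound 2 to compound 3 (0.19 log units; within the scatter), so this position tolerates the loss of one ring nitrogen without a change that can be told from scatter. Compound 3 also isolates the second change: hydrogen in place of phenyl on the amide-type nitrogen gives a 1.7-fold lower number from compound 1 to compound 3 (0.23 log units; within the scatter), so the gap between compound 1 and compound 2, itself beyond the scatter, splits into two steps that each stay within it. Nothing available explains either step.

Still open, on these data alone, is whether an open-chain amine or a carboxylic acid in place of these rings, or a longer chain, would move the number beyond the scatter. Also open, as far as these compounds go, is how a methyl group on the amide-type nitrogen would compare.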